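Fluorine scan on the chalcone-type benzoxaborole series

The compounds below may be only part of what the source reports. "The series", "measured", "known", "first", "only" and "open" are said of these compounds alone.

Measured compounds, with values in a toxicity assay on MCF-10A cells (Homo sapiens) for cytotoxicity, read by MTT assay, with a stated time of 48 h; on this read-out lower numbers stand for stronger inhibition and higher numbers for weaker inhibition:
compound 1, `O=C(/C=C/c1ccc2c(c1)B(O)OC2)c1ccccc1`, 15900 nM
compound 2, `O=C(/C=C/c1ccc2c(c1)B(O)OC2)c1cccnc1`, 34400 nM
compound 3, `Nc1ccc(C(=O)/C=C/c2ccc3c(c2)B(O)OC3)cc1`, 19900 nM

Compound 1 is the reference of the set. Relative to it, the step of a 1.3-fold higher number from compound 1 to compound 3 (0.10 log units; within the scatter) stays within the scatter, while the step of a 2.2-fold higher number from compound 1 to compound 2 (0.34 log units; beyond the scatter) goes beyond it; between the other two, a 1.7-fold lower number from compound 2 to compound 3 (0.24 log units; within the scatter) is again within the scatter. Compound 4, `O=C(/C=C/c1ccc2c(c1)B(O)OC2)c1cccc(F)c1`, differs from compound 1 by fluoro in place of hydrogen on an aromatic carbon. For the measured compounds named here, no measured step involves this group, so the nearest guides are the two changes on the same ring end of compound 1, one modest and one within the scatter. A step within the scatter is therefore expected, with the change a 1.1-fold lower number from compound 1 to compound 4 (0.03 log units; within the scatter) estimated. Compound 4 is expected at 15000 nM, within 7000 nM to 35000 nM.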

Compound 4, half-maximal inhibitory concentration: 15800 nM
Beside the measured number, compound 4's estimate is 1.1-fold (0.02 log units) below it; low and high end bracket the measured number.
By their numbers in this assay, from the lowest: compounds 4, 1, 3 and 2 (each within the scatter of the next, the first and the last beyond it).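

In this assay, fluoro on this aromatic carbon, meta to a large group, brings no shift beyond the scatter (a 1.0-fold lower number from compound 1 to compound 4 (0.00 log units; within the scatter)). The 3-fluorophenyl end also stays within the scatter of the 4-aminophenyl end (a 1.3-fold lower number from compound 3 to compound 4 (0.10 log units; within the scatter)), while it stands apart from the pyridin-3-yl end (a 2.2-fold lower number from compound 2 to compound 4 (0.34 log units; beyond the scatter)), so this ring end accepts fluoro without a readable change. No measured evidence explains these steps. Open, on these data alone, is whether chloro or methoxy at the same place, or fluoro elsewhere on this ring, would stay as close to compound 1.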